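The source may hold more compounds than are shown below. What is called first, only, known or untested is meant among the compounds shown, and "the series" means these compounds.

Three close relatives of one shared core have been tested in a functional assay on A549 cells (Homo sapiens) for antiproliferative activity, read by MTT assay, with a stated time of 48 h; on this read-out lower numbers stand for stronger inhibition and higher numbers for weaker inhibition. Compound 1 `N#CC1=C(N)Oc2c(c3nc4ccccc4nc3c3ccccc23)C12C(=O)N(Cc1cnnn1-c1ccc(Cl)cc1)c1ccccc12` carries a 4-chlorophenyl on an aromatic nitrogen; compound 2 `N#CC1=C(N)Oc2c(c3nc4ccccc4nc3c3ccccc23)C12C(=O)N(Cc1cnnn1-c1cccc(Cl)c1)c1ccccc12` has a 3-chlorophenyl there instead, and compound 3 `N#CC1=C(N)Oc2c(c3nc4ccccc4nc3c3ccccc23)C12C(=O)N(Cc1cnnn1-c1ccc([N+](=O)[O-])cc1)c1ccccc12` a 4-nitrophenyl. In this assay compound 2 gives 32600 nM. For compound 1 the read-out is only a limit of the assay, > 50000 nM. For compound 3 it is likewise only a limit, > 50000 nM. So compound 3 stands at the limit of > 50000 nM in this assay, at which 2 of the 3 values shown sit. The step of an at least 1.5-fold lower number from compound 1 to compound 2 (0.18 log units; that floor lies within the scatter) lies within the scatter, the step of an at least 1.5-fold higher number from compound 2 to compound 3 (0.18 log units; that floor lies within the scatter) has a floor that lies within the scatter, and the step that the two limits leave unreadable from compound 1 to compound 3 cannot be read at all.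

Compound 4 `CC(=O)Nc1ccc(-n2nncc2CN2C(=O)C3(C(C#N)=C(N)Oc4c3c3nc5ccccc5nc3c3ccccc43)c3ccccc32)cc1` is the next relative: acetamido in place of nitro on an aromatic carbon. For the measured compounds named here, no measured step exchanges the nitro for anything other than chloro, so the only guide is that compound 3 sits at a limit and that the steps among the three measured compounds are all small or unreadable. The step expected in this assay is therefore a step that the limit leaves unreadable from compound 3 to compound 4, nothing readable beyond the scatter. Compound 4 is thus estimated to come out at about 60000 nM, somewhere between 20000 nM and 200000 nM, quite possibly again only as a limit.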

Compound 4, half-maximal inhibitory concentration: > 50000 nM
Compound 4: a limit, no number; the forecaster's own chance of this, stated with the estimate: 70%; the middle value does not contradict the limit.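

In this assay compound 4 gives > 50000 nM, which is a limit of the assay and not a number. The 4-acetamidophenyl is the first group shown at this position with a hydrogen-bond donor, yet the read-out stays where most of this small series sits: the limit of > 50000 nM in this assay, at which 3 of the 4 values shown sit. For the compounds shown here, the one step that can be read is an at least 1.5-fold higher number from compound 2 to compound 4 (0.18 log units; that floor lies within the scatter), and the steps that join two limits cannot be read, so swapping the nitro or the chloro for acetamido has no measurable size here.

On these data alone, how an amine or a carboxylic acid on an aromatic carbon of this ring would read stays open, and so does whether any such group would give a clear number rather than another limit. Also open, as far as these compounds go, is where the true values of compound 1, compound 3 and compound 4 lie beyond the limit, and whether these three differ from one another at all.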